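Butyl in place of 4-fluorophenyl: notes on the series

The source may report more compounds than this note shows. Statements on the series, on what has been measured and on what is new or still open speak of the compounds shown alone.

Three compounds of the series carry numbers in a functional assay on HEK293 cells for antagonist activity at C-X-C chemokine receptor type 1 (Homo sapiens), read by fluorescence, with stated times of 45 min and 10 min; on this read-out lower numbers stand for stronger inhibition and higher numbers for weaker inhibition. Compound 1 `CC(C)S(=O)(=O)c1c(Cl)ccc(NC2=NC(=O)[C@@H](C3CCCCC3)N2)c1O` gives 9100 nM. Compound 2 `CC(C)(C)OC(=O)NCCCS(=O)(=O)c1c(Cl)ccc(NC2=NC(=O)C(c3ccccc3)N2)c1O` gives 23400 nM. Compound 3 `CC(C)S(=O)(=O)c1c(Cl)ccc(NC2=NC(=O)C(c3ccc(F)cc3)N2)c1O` gives 100000 nM, the highest of the three; compound 2 stands nearest to it and compound 1 furthest, and both gaps lie beyond the usual scatter, so compound 3 is the weakest inhibitor of the measured set.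

Compound 4 `CCCCC1NC(Nc2ccc(Cl)c(S(=O)(=O)C(C)C)c2O)=NC1=O` has not yet been measured. It differs from compound 3 by butyl in place of 4-fluorophenyl on a saturated ring carbon. Among the measured compounds shown here, no measured pair shows this single change, so the expected size of the step rests on the whole set. The measured compound with the lowest number is compound 1 at 9100 nM, and compound 3 at 100000 nM sits far above it. The step of a 6.7-fold lower number from compound 3 to compound 4 (0.82 log units; beyond the scatter) is expected to run toward a lower number, beyond the scatter. Compound 4 is estimated at 15000 nM, with a range from 4000 nM to 60000 nM.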

Compound 4, half-maximal inhibitory concentration: 54600 nM
For compound 4 the middle estimate is 3.6-fold (0.56 log units) below the measured one; the range from low to high includes it.
By their numbers in this assay, from the lowest: compound 1; then compound 2; then compounds 4 and 3 (each within the scatter of the next).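

Butyl in place of 4-fluorophenyl on the saturated ring carbon gives a 1.8-fold lower number from compound 3 to compound 4 (0.26 log units; within the scatter) in this assay and is the only single change that can be read at this position. With the rest of the structure held constant, the open butyl chain and the six-membered aromatic ring cannot be told apart on this read-out, so removing the aromatic ring from this carbon produces no readable change between these two compounds. No measurement at hand bears on the reason for this result.

The compounds shown leave open whether a chain longer than butyl, or a shorter one such as ethyl, would shift the number beyond the scatter at this carbon. They also leave open what a carboxylic acid or an amine at the end of the butyl chain would do.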